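This account rests on a few compounds, and the source may have more. Where it says the series, first, only, none or still open, it means among the compounds named here.

Among the measured compounds shown here, in a functional assay on NCI-H522 cells (Homo sapiens) for inhibition, read by sulforhodamine B assay, with a stated time of 48 h (a higher number here means a weaker inhibitor of growth, a lower number a stronger inhibitor of growth), only two compounds have numbers so far. Compound 1 `CCCCCCCCCCCC[C@@H](O)[C@H]1CC[C@H]([C@H](O)CCCCCCCCCCNCc2ccnn2C)O1` gives 1290 nM, while compound 2 `CCCCCCCCCCCC[C@@H](O)[C@H]1CC[C@H]([C@H](O)CCCCCCCCCCC(=O)Nc2ccnn2C)O1` gives 28800 nM, the higher of the two numbers and so the weaker inhibitor of growth. Compound 3 `CCCCCCCCCCCC[C@@H](O)[C@H]1CC[C@H]([C@H](O)CCCCCCCCCCOC(=O)c2ccnn2C)O1` has not yet been measured. It keeps the shared core of compound 2 and changes one group: ((1-methyl-1H-pyrazol-5-yl)carbonyl)oxy in place of (1-methyl-1H-pyrazol-5-yl)carbamoyl on a saturated chain carbon, ten or more bonds along the chain from an oxygen on a saturated carbon and a saturated ring carbon. The change sits on a saturated chain carbon.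

For the measured compounds named here, only one measured step bears on this place: a 22-fold higher number from compound 1 to compound 2 (1.35 log units; beyond the scatter). That step is large and shows that a swap here can move the number well beyond the scatter. However, it exchanges a different pair of groups, and no measured step covers ((1-methyl-1H-pyrazol-5-yl)carbonyl)oxy. With no evidence for a direction, no step beyond the scatter is expected in this assay, and the estimate starts from compound 2 at 28800 nM. The expected step is a 1.4-fold lower number from compound 2 to compound 3 (0.16 log units; within the scatter). For compound 3 the estimated value is 20000 nM, with an expected range from 6000 nM to 60000 nM.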

Compound 3, concentration for 50% growth inhibition: 6310 nM
Beside the measured number, compound 3's estimate is 3.2-fold (0.50 log units) above it; measured number inside the range.
By their numbers in this assay, from the lowest: compound 1; then compound 3; then compound 2.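

In this assay, the step from the carbamoyl link to the carbonyloxy link gives a 4.6-fold lower number from compound 2 to compound 3 (0.66 log units; beyond the scatter). This shows that the number responds at this place even when the heavy-atom count and the aromatic ring stay the same, and the link changes only by one oxygen for one nitrogen, with the loss of the hydrogen-bond donor. The ester does not match the amine-linked compound, however, as a 4.9-fold higher number from compound 1 to compound 3 (0.69 log units; beyond the scatter) shows, so the three links now fall in a clear order, with the amine lowest, the ester in the middle and the amide highest. Nothing measured here explains why the links differ in this way.

The three compounds do not separate the effect of losing the donor from the effect of the changed atoms and their arrangement in the link, since each link differs from the others in more than one feature. An ether or a sulfonamide at this same place on the saturated chain carbon, or a longer chain carrying the amine, would show whether the order of the links holds beyond these three compounds.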